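The compounds below may be only part of what the source reports. "The series", "measured", "known", "first", "only" and "open" are said of these compounds alone.

Compound 1 `COc1c(N2CCN(CC/C(C)=N/O)C(C)C2)c(F)cc2c(=O)c(C(=O)O)cn(C3CC3)c12`: 44.2 ug/mL
Compound 2 `COc1c(N2CCN(CC/C(C)=N/NC(N)=O)C(C)C2)c(F)cc2c(=O)c(C(=O)O)cn(C3CC3)c12`: 31.3 ug/mL

In an ADME assay on Vero cells (Chlorocebus sabaeus) for cytotoxicity, read by MTT assay, with a stated time of 72 h (on this read-out higher numbers stand for lower toxicity in this test and lower numbers for higher toxicity in this test), compound 2, at 31.3 ug/mL, lies within the scatter of compound 1. Compound 3 `COc1c(N2CCN(CC/C(C)=N/Nc3ccccc3)C(C)C2)c(F)cc2c(=O)c(C(=O)O)cn(C3CC3)c12` carries phenyl in place of carbamoyl on an amine nitrogen. Among the compounds with values here, the only measured step bearing on this is a 1.4-fold lower number from compound 1 to compound 2 (0.15 log units; within the scatter), with ureido in place of hydroxy on a double-bonded nitrogen. Within the data shown here, no measured step introduces phenyl, so the expectation is loose. In this assay, the expected step is a 1.2-fold lower number from compound 2 to compound 3 (0.08 log units; within the scatter), none beyond the scatter. For compound 3 the estimate is 26 ug/mL, with an expected range of 10 ug/mL to 60 ug/mL.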

Compound 3, half-maximal cytotoxic concentration: 62.5 ug/mL
Estimate against measurement, compound 3: 2.4-fold (0.38 log units) below, and the stated range ends below it.
By their numbers in this assay, from the lowest: compounds 2, 1 and 3 (each within the scatter of the next).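

In this assay the change from ureido to anilino gives a 2.0-fold higher number from compound 2 to compound 3 (0.30 log units; within the scatter) and stays within the scatter, as does the other new step, a 1.4-fold higher number from compound 1 to compound 3 (0.15 log units; within the scatter). This position on the double-bonded nitrogen therefore takes a six-membered aromatic ring of carbon only, and hydroxy, ureido and anilino read alike here. Nothing measured bears on the origin of these numbers. Going by these compounds, what a benzyl group, a pyridine ring or a short alkyl chain on the amine nitrogen would give remains open, as does the effect of a chlorine atom on the phenyl ring.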